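Methoxy in Place of Nitro: Expected Change in Cytotoxicity

This account rests on a few compounds, and the source may have more. Where it says the series, first, only, none or still open, it means among the compounds named here.

Measured compounds:
compound 1, `COc1ccc(-c2nc3cc(C(F)(F)F)ccc3[nH]2)c(OC)c1`, > 100000 nM
compound 2, `O=[N+]([O-])c1ccc(-c2nc3cc(C(F)(F)F)ccc3[nH]2)cc1`, 45000 nM

Within the data shown here, in an ADME assay on Vero cells (Chlorocebus sabaeus) for cytotoxicity (on this read-out higher numbers stand for lower toxicity in this test and lower numbers for higher toxicity in this test), compound 2 gives 45000 nM, the only number among the values shown. For compound 1 the result is a limit of the assay, > 100000 nM. Compound 3, `COc1ccc(-c2nc3cc(C(F)(F)F)ccc3[nH]2)cc1`, has not yet been measured; it differs from compound 2 by methoxy in place of nitro on an aromatic carbon. Among the measured compounds shown here, no step between measured compounds connects the two, so the size of the change can only be estimated. The estimate rests on compound 1, which carries methoxy groups and sits at the limit of > 100000 nM in this assay, at which 1 of the 2 values shown sits, so compound 3 is expected to move toward lower toxicity, beyond the usual scatter, with an expected step of a 2.2-fold higher number from compound 2 to compound 3 (0.35 log units; beyond the scatter). Compound 3 is therefore estimated to give 100000 nM, within a range from 40000 nM to 250000 nM, and it may well reach the limit of this assay.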

Compound 3, half-maximal cytotoxic concentration: 15000 nM
For compound 3 the middle estimate is 6.7-fold (0.82 log units) above the measured one; the measured number lies below the stated range.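

In this assay, among these compounds, methoxy in place of nitro on this aromatic carbon, para to a large group, gives a 3.0-fold lower number from compound 2 to compound 3 (0.48 log units; beyond the scatter), so here methoxy goes with higher toxicity in this test than nitro, a comparison the earlier compounds could not offer. Hydrogen in place of the other methoxy of compound 1 gives an at least 6.6-fold lower number from compound 1 to compound 3 (0.82 log units; beyond the scatter), which shows that the compounds with one and two methoxy groups are clearly separated in this test. Compound 1 stands at a limit of the assay, so that step marks a bound and not a measured size: the limit of > 100000 nM in this assay, at which 1 of the 3 values shown sits.

On these data alone, whether the lower number belongs to methoxy in particular remains open, since an amine, a carboxylic acid or a longer chain at this position might give a different result. The compounds shown also leave open whether the step from nitro to methoxy would be the same on a different core.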